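Oxan-4-yl to methyl on an ether oxygen

This account rests on a few compounds, and the source may have more. Where it says the series, first, only, none or still open, it means among the compounds named here.

In an ADME assay on CEM-SS cells (Homo sapiens) for cytotoxicity, read by XTT assay (on this read-out lower numbers stand for higher toxicity in this test and higher numbers for lower toxicity in this test), the values so far are these, each a limit of the assay and not a number:
Compound 1 `CN(O)C(=O)c1cc2c(CO)cn(Cc3ccc(F)cc3)c2cn1` gives > 266000 nM
Compound 2 `COCCOCc1cn(Cc2ccc(F)cc2)c2cnc(C(=O)N(C)O)cc12` gives > 100000 nM
Compound 3 `CN(O)C(=O)c1cc2c(COC3CCOCC3)cn(Cc3ccc(F)cc3)c2cn1` gives > 100000 nM

Compound 3 stands at a limit, > 100000 nM, with no exact number known. Compound 4 `COCc1cn(Cc2ccc(F)cc2)c2cnc(C(=O)N(C)O)cc12` carries methyl in place of oxan-4-yl on an oxygen on a saturated carbon. The measured changes on this same oxygen are a step that the two limits leave unreadable from compound 1 to compound 2, a step that the two limits leave unreadable from compound 1 to compound 3 and a step that the two limits leave unreadable from compound 2 to compound 3, so none offers a size to carry over. Because of the limit of > 100000 nM in this assay, at which 2 of the 3 values shown sit, for compound 3 , no step beyond the scatter is expected in this assay, and the expected step is a number no higher from compound 3 to compound 4 (the limit leaves the size open) in size. The estimate for compound 4 is 100000 nM, with an expected range from 30000 nM to 300000 nM, and it may well be reported as a limit too.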

Compound 4, half-maximal cytotoxic concentration: 266000 nM
Estimate against measurement, compound 4: 2.7-fold (0.42 log units) below; the measured number falls inside the stated range.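

In this assay, for the compounds shown here, compound 4 gives 266000 nM as an exact number, the first for any group on this ether oxygen. Compound 3 gives > 100000 nM as a limit of the assay and not a number. Read as a direction only, the data give a number no higher from compound 1 to compound 4 (the limit leaves the size open) and no more. The steps to compound 4 from compound 2 and compound 3 cannot be read for size, so swapping oxan-4-yl for methyl has no measured effect that can be stated. The compounds shown leave open how a longer chain, an amine or a carboxylic acid on this oxygen would read, and whether any group here would bring the number down by more than the usual scatter.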